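From a Diethylamino Chain to a Dimethylamino Chain

The source may report more compounds than this note shows. Statements on the series, on what has been measured and on what is new or still open speak of the compounds shown alone.

In a functional assay on A549 cells (Homo sapiens) for antiproliferative activity, read by MTT assay, with a stated time of 48 h (a lower number here means a stronger inhibitor, a higher number a weaker inhibitor), compound 2 `CCN(CC)CCn1c(N)c(-c2nc3cc(Cl)ccc3[nH]2)c2nc(C#N)c(C#N)nc21` gives > 50000 nM. That value is a limit of the assay and not a number.

Compound 3 `CN(C)CCCn1c(N)c(-c2nc3cc(Cl)ccc3[nH]2)c2nc(C#N)c(C#N)nc21` keeps the core of compound 2 and alters only the side chain: (dimethylamino)methyl in place of diethylamino on a saturated chain carbon, two bonds along the chain from an aromatic nitrogen. Put simply, (dimethylamino)methyl stands in place of diethylamino on a saturated chain carbon, two bonds along the chain from an aromatic nitrogen. The 2-(diethylamino)ethyl chain thus becomes 3-(dimethylamino)propyl.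

For the measured compounds named here, the only numerical guide is a neighbour that differs from compound 3 elsewhere as well. Compound 1 `CN(C)CCCn1c(N)c(-c2nc3ccccc3o2)c2nc(C#N)c(C#N)nc21` carries the same 3-(dimethylamino)propyl chain and gives 7170 nM in this assay. With that value of compound 1 as the sole reference, a move toward stronger inhibition, beyond the usual scatter, seems likely, though the other structural differences make its size uncertain. The expected step of an at least 2.7-fold lower number from compound 2 to compound 3 (0.44 log units; beyond the scatter) is therefore only a rough estimate. Compound 3 is expected to give about 18000 nM, with an estimated range of 5000 nM to 50000 nM.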

Compound 3, half-maximal inhibitory concentration: > 50000 nM
Compound 3: no number, only a limit; the forecaster's own chance of this, stated with the estimate: 30%; at least 2.7-fold (0.44 log units) between middle value and limit.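

With the 3-(dimethylamino)propyl chain held the same, compound 1 and compound 3 differ in one place, where 5-chloro-1H-benzimidazol-2-yl stands in place of 1,3-benzoxazol-2-yl on an aromatic carbon. In this assay this change gives an at least 6.9-fold higher number from compound 1 to compound 3 (0.84 log units; beyond the scatter), so the group on that aromatic carbon clearly affects the read-out when this chain is present. The effect of the chain change itself cannot be read, because compound 2 and compound 3 both stand at a limit of the assay and not at a number: the limit of > 50000 nM in this assay, at which 2 of the 3 values shown sit.

The compounds shown do not tell how far past that limit compound 2 and compound 3 lie, so it remains open whether going from 2-(diethylamino)ethyl to 3-(dimethylamino)propyl changes anything with the 5-chloro-1H-benzimidazol-2-yl group in place. On these data alone, it is also open whether a morpholine ring at the end of the chain, or the 2-(diethylamino)ethyl chain paired with 1,3-benzoxazol-2-yl, would give a value that can be compared directly with compound 1.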